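The source may report more compounds than this note shows. Statements on the series, on what has been measured and on what is new or still open speak of the compounds shown alone.

In a functional assay on OVCAR-3 cells (Homo sapiens) for antiproliferative activity, read by spectrophotometry, with a stated time of 2 days (a higher number here means a weaker inhibitor of growth, a lower number a stronger inhibitor of growth), compound 3 `Cc1cc(Cl)ccc1Nc1ncc(C(F)(F)F)c(N2Cc3cccc(N(C)S(C)(=O)=O)c3C2)n1` gives only a limit, > 30000 nM. Compound 1 `Cc1ccc(Nc2ncc(C(F)(F)F)c(N3Cc4cccc(N(C)S(C)(=O)=O)c4C3)n2)cc1C` also gives only a limit, > 30000 nM. Compound 2 `CN(c1cccc2c1CN(c1nc(Nc3ccc(C(F)(F)F)cc3)ncc1C(F)(F)F)C2)S(C)(=O)=O` likewise gives only a limit, > 30000 nM. Going by the values given here, the series so far therefore sits at the limit of > 30000 nM in this assay, at which 3 of the 3 values shown sit.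

Compound 4 `CN(c1cccc2c1CN(c1nc(Nc3cc(Cl)cc(C(F)(F)F)c3)ncc1C(F)(F)F)C2)S(C)(=O)=O` differs from compound 3 by 3-chloro-5-(trifluoromethyl)phenyl in place of 4-chloro-2-methylphenyl on a nitrogen on an aromatic ring, with 3-chloro-5-(trifluoromethyl)phenyl in place of 4-chloro-2-methylphenyl on a nitrogen on an aromatic ring. Three changes at this same place bear on it: a step that the two limits leave unreadable from compound 1 to compound 2, a step that the two limits leave unreadable from compound 1 to compound 3 and a step that the two limits leave unreadable from compound 2 to compound 3. None has a readable size, so they offer no direction, and no step beyond the scatter is expected in this assay. The expected change is an at least 1.2-fold lower number from compound 3 to compound 4 (0.07 log units; that floor lies within the scatter). For compound 4 the estimate is 25000 nM, with an expected range from 8000 nM to 40000 nM.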

Compound 4, concentration for 50% growth inhibition: 21500 nM
The estimate for compound 4 lay 1.2-fold (0.07 log units) above the measured number; low and high end bracket the measured number.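

Compound 4 is the only compound shown in this assay with a number rather than a limit, so 3-chloro-5-(trifluoromethyl)phenyl on this nitrogen gives the only readable steps: an at least 1.3-fold lower number from compound 3 to compound 4 (0.14 log units; that floor lies within the scatter), an at least 1.3-fold lower number from compound 2 to compound 4 (0.14 log units; that floor lies within the scatter) and an at least 1.3-fold lower number from compound 1 to compound 4 (0.14 log units; that floor lies within the scatter). These are floors only, and the steps among the other three compounds cannot be read. Those other three remain limits: the limit of > 30000 nM in this assay, at which 3 of the 4 values shown sit.

Still open, as far as these compounds go, is how far compounds 1, 2 and 3 lie from compound 4. Also open, from the compounds shown here alone, is whether an amine, a carboxylic acid or a nitrile on this phenyl ring would give a lower number.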